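From a Chlorothiophene Carbonyl to a Carboxyethyl Carbonyl

The source may report more compounds than this note shows. Statements on the series, on what has been measured and on what is new or still open speak of the compounds shown alone.

Measured compounds:
compound 1, `CCOC(=O)C1=C(C)NC(C)=C(C(=O)OCC)C1c1ccc(OCC(=O)NCc2ccccc2)cc1`, 8.9%
compound 2, `CCOC(=O)C1=C(C)NC(C)=C(C(=O)OCC)C1c1ccc(OCC(=O)NNC(=O)c2sccc2Cl)cc1`, 57.2%
compound 3, `CCOC(=O)C1=C(C)NC(C)=C(C(=O)OCC)C1c1ccc(OCc2nnc(S)o2)cc1`, 61.7%

Three compounds sharing one core were measured in a functional assay on the whole organism (strain Wistar) for inhibition, with Rattus norvegicus as the target, read by paw edema, with stated times of 30 min and 2 h, at a dose of 20 mg/kg; a lower number here means less inhibition, a higher number more inhibition at the dose given (going by the name of the read-out). Compound 1 gives 8.9%, compound 2 gives 57.2%, and compound 3 gives 61.7%. Compound 2 stands second highest of the three numbers, but its gap to compound 3 is a number 4.5 percentage points higher from compound 2 to compound 3 (within the scatter), so the two cannot be ordered; only compound 1 is clearly apart, the step being a number 48.3 percentage points higher from compound 1 to compound 2 (beyond the scatter).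

Compound 4, `CCOC(=O)C1=C(C)NC(C)=C(C(=O)OCC)C1c1ccc(OCC(=O)NNC(=O)CCC(=O)O)cc1`, is not yet measured in this assay . It differs from compound 2 by 2-carboxyethyl in place of 3-chlorothiophen-2-yl on a carbonyl carbon. For the measured compounds named here, two measured steps bear on this change. The step of a number 48.3 percentage points higher from compound 1 to compound 2 (beyond the scatter) shows that the group carried by the amide-type nitrogen can move the number a great deal, while the step of a number 4.5 percentage points higher from compound 2 to compound 3 (within the scatter) shows that exchanging one sulfur-containing heterocycle for another at the far end of the chain left the number where it was. Going by the values given here, no measured step removes the aromatic ring altogether, so the direction is open; the estimate for compound 4 therefore sits somewhat below compound 2, with a wide range. Compound 4 is expected to give 46% in this assay , between 25% and 66%. The expected step is a number 11.2 percentage points lower from compound 2 to compound 4 (beyond the scatter).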

Compound 4, a percentage reported as inhibition, in the whole organism at one dose (the size of the read-out at that dose, not a potency): 57.8%
The estimate for compound 4 lay 11.8 percentage points below the measured number; measured number inside the range.
By their numbers in this assay, from the lowest: compound 1; then compounds 2, 4 and 3 (each within the scatter of the next).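

Replacing 3-chlorothiophen-2-yl by 2-carboxyethyl on the carbonyl carbon gave a number 0.6 percentage points higher from compound 2 to compound 4 (within the scatter) in this assay, so at this dose a ring on this carbon is not needed to keep the number where it stands. The open ((2-carboxyethyl)carbonyl)amino end of the chain also cannot be told apart from the 5-sulfanyl-1,3,4-oxadiazol-2-yl group, which carries a five-membered aromatic ring, the comparison reading a number 3.9 percentage points lower from compound 3 to compound 4 (within the scatter). Set against benzyl on the amide-type nitrogen, the same group gave a number 48.9 percentage points higher from compound 1 to compound 4 (beyond the scatter), so the large gap from the benzyl compound, seen before with the (3-chlorothiophen-2-yl)carbonyl group, does not depend on that ring or on its sulfur and chlorine.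

The compounds shown cannot tell whether the carboxylic acid at the end of 2-carboxyethyl itself counts, a question that an ethyl ester or an amine in its place, or a longer chain, would address. Nothing at hand gives a reason why such different groups read so closely, and each reading is the size of the effect at one dose, not a potency.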